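The compounds below may be only part of what the source reports. "The series", "measured", "known", "first", "only" and "open" are said of these compounds alone.

Measured so far:
- compound 1, `COc1cc(/C=C/c2cc(C)no2)ccc1O`: 36200 nM in an ADME assay on HEK293 cells (Homo sapiens) for cytotoxicity, read by MTT assay, with a stated time of 72 h; a higher number here means a weaker inhibitor, a lower number a stronger inhibitor
- compound 2, `CC(=O)/C=C(O)/C=C/c1ccc(O)c(O)c1`: 7300 nM
- compound 3, `Cc1cc(/C=C/c2ccc(O)cc2)on1`: 50200 nM

Compound 3 has the highest number of the three. Its nearest neighbour is compound 1, and the step of a 1.4-fold higher number from compound 1 to compound 3 (0.14 log units; within the scatter) lies within the scatter, so the two cannot be ordered. Compound 2 stands furthest away, with a number beyond the scatter from compound 3.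

Compound 4, `Cc1cc(/C=C/c2ccc(O)c(O)c2)on1`, differs from compound 3 by hydroxy in place of hydrogen on an aromatic carbon. Among the measured compounds shown here, no measured step shows this exact change, as hydroxy in place of hydrogen on an aromatic carbon appears nowhere between the measured pairs; the only step available, a 1.4-fold higher number from compound 1 to compound 3 (0.14 log units; within the scatter), concerns a methoxy group and was within the scatter. Compound 2 also carries two hydroxy groups, but its core differs. A step toward a lower number is expected for compound 4, a 2.0-fold lower number from compound 3 to compound 4 (0.30 log units; within the scatter), though it may fall within the scatter. Compound 4 is therefore estimated at 25000 nM, in the range 8000 nM to 60000 nM.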

Compound 4, half-maximal inhibitory concentration: 13000 nM
For compound 4 the middle estimate is 1.9-fold (0.28 log units) above the measured one; the measured number falls inside the stated range.
By their numbers in this assay, from the lowest: compounds 2 and 4 (each within the scatter of the next); then compounds 1 and 3 (each within the scatter of the next).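

In this assay the step of a 3.9-fold lower number from compound 3 to compound 4 (0.59 log units; beyond the scatter) shows that a hydroxy on this aromatic carbon, ortho to a hydroxy group, does move the number. Methoxy at the same place could not be told apart from hydrogen, yet the step of a 2.8-fold lower number from compound 1 to compound 4 (0.44 log units; beyond the scatter) shows that hydroxy there also stands apart from methoxy. Nothing given here explains this difference. Still open, on these data alone, is how an amine, a fluorine or an ethoxy group on this carbon would read, and whether removing either hydroxy from compound 2 would give a similar step.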